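The compounds below may be only part of what the source reports. "The series", "measured", "known", "first", "only" and "open" are said of these compounds alone.

Of the compounds shown here, two built on a shared core have been tested in an assay on isolated protein for inhibition of malate dehydrogenase, mitochondrial (Sus scrofa), with stated times of 45 min and 30 min; on this read-out lower numbers stand for stronger inhibition and higher numbers for weaker inhibition. Compound 1 `C=Cc1ccc(S(=O)(=O)Nc2ccc(-c3nc4ccccc4o3)cc2)cc1` reaches only a limit of the assay, > 63000 nM. Compound 2 `O=S(=O)(Nc1ccc(-c2nc3ccccc3o2)cc1)c1cccc(C(F)(F)F)c1` likewise reaches only a limit, > 63000 nM. Compound 2 therefore stands at the limit of > 63000 nM in this assay, at which 2 of the 2 values shown sit, with no measured number that would set it apart from compound 1. The next compound, compound 3 `O=S(=O)(Nc1ccc(-c2nc3ccccc3o2)cc1)c1cccc(F)c1`, differs from compound 2 in one place: fluoro in place of trifluoromethyl on an aromatic carbon. Among the compounds with values here, because both measured values are limits, there is no measured step between measured compounds to lean on, and in this assay the expectation is a step from compound 2 to compound 3 of no more than the usual scatter, most likely ending again at a limit rather than at a number. The estimated value for compound 3 is 63000 nM, with a range from 20000 nM to 200000 nM. The step this estimate implies is a number no higher from compound 2 to compound 3 (the limit leaves the size open).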

Compound 3, half-maximal inhibitory concentration: > 63000 nM
Compound 3: only a limit was reported (the forecaster's own chance of this, stated with the estimate: 80%); the middle value lies on the limit itself.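

Within the data shown here, compound 3 gives only a limit of the assay, > 63000 nM, as do compound 1 and compound 2, so no step among them can be read. The compounds shown leave open whether swapping these groups on the shared core changes inhibition at all in this assay.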